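A few compounds are considered here, and "the series" means these few. Any claim that something is new, unique, unknown or untested is made for them only; others in the source may bear on it.

In a functional assay on MDA-MB-231 cells (Homo sapiens) for inhibition, read by MTT assay, with a stated time of 48 h (on this read-out higher numbers stand for weaker inhibition and lower numbers for stronger inhibition), three compounds share one core and differ in the chain bearing selenium. Compound 1 (`COc1ccc(N(C)c2nc(C)nc3ccccc23)cc1OCCC[Se]C#N`) gives 815 nM while compound 2 (`COc1ccc(N(C)c2nc(C)nc3ccccc23)cc1OCC[Se]C#N`) gives 13 nM and compound 3 (`COc1ccc(N(C)c2nc(C)nc3ccccc23)cc1OCCCC[Se]C#N`) gives 1350 nM in this read-out. Compound 3 thus lies within the scatter of compound 1 and far from compound 2. Compound 4 (`COc1ccc(N(C)c2nc(C)nc3ccccc23)cc1OCCN`) departs from compound 3 by one change (one nitrogen atom in place of a group of 5 heavy atoms (3 carbon, 1 nitrogen, 1 selenium; no ring), on a saturated chain carbon, two bonds along the chain from an oxygen on an aromatic ring). Two measured steps at that same place bear on it (a 100-fold higher number from compound 2 to compound 3 (2.02 log units; beyond the scatter) and a 63-fold lower number from compound 1 to compound 2 (1.80 log units; beyond the scatter)) and both are large. The third (a 1.7-fold higher number from compound 1 to compound 3 (0.22 log units; within the scatter)) stays within the scatter. None of them brings in an amino group, so they guide only loosely. A moderate move to a lower number is expected (a 4.5-fold lower number from compound 3 to compound 4 (0.65 log units; beyond the scatter)) in this assay here. For compound 4 the estimate is 300 nM with an expected range from 30 nM to 3000 nM in this read-out.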

Compound 4, half-maximal inhibitory concentration: 682 nM
Compound 4: middle estimate off by 2.3-fold (0.36 log units), on the low side; the range from low to high includes it.
By their numbers in this assay, from the lowest: compound 2; then compounds 4, 1 and 3 (each within the scatter of the next).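

In this assay, the amino group, which carries no selenium, reads level with the groups of 4 and 5 heavy atoms: a 1.2-fold lower number from compound 1 to compound 4 (0.08 log units; within the scatter) and a 2.0-fold lower number from compound 3 to compound 4 (0.30 log units; within the scatter). Only the group of 3 heavy atoms stands apart, with a 52-fold higher number from compound 2 to compound 4 (1.72 log units; beyond the scatter), so among these compounds a selenium-bearing chain does not in itself give a low number; compound 2 alone does. No measurement shown accounts for this. The compounds shown leave open whether a thiocyanate in place of the selenium-bearing end of compound 2 would keep its number, and how an amine on a longer chain would read.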